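The source may report more compounds than this note shows. Statements on the series, on what has been measured and on what is new or still open speak of the compounds shown alone.

Measured compounds: compound 1, `c1csc(-c2cn3ccnc3c(-c3ccc4ncn(C5CCCCC5)c4c3)n2)c1`, with 13.2%; compound 2, `CCc1ccc(-c2cn3ccnc3c(-c3ccc4ncn(Cc5ccccc5)c4c3)n2)cc1`, with 45.9%.

Of the compounds shown here, two have been measured in a functional assay on NCI-H522 cells (Homo sapiens) for inhibition, read by sulforhodamine B assay, with a stated time of 48 h, tested at 10 uM; a lower number here means less inhibition, a higher number more inhibition at the concentration tested (going by the name of the read-out). Compound 2 gives 45.9%, the higher of the two numbers, and compound 1 gives 13.2%, a number that lies beyond the usual scatter below it. Going by the values given here, no pair of these two compounds differs in a single place, so no single step between them can be read from the data.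

Compound 3, `Cc1cccc(-c2cn3ccnc3c(-c3ccc4ncn(Cc5ccccc5)c4c3)n2)c1`, has not yet been measured. It differs from compound 2 in one place: 3-methylphenyl in place of 4-ethylphenyl on an aromatic carbon. Nothing measured here shows how this change alone acts on this assay, so the expectation rests on compound 2 alone. A moderate drop from compound 2 is expected, a number 9.9 percentage points lower from compound 2 to compound 3 (within the scatter), possibly no change beyond the scatter. Compound 3 is therefore estimated at 36%, within a range from 15% to 56%.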

Compound 3, a percentage reported as inhibition, at one concentration (the size of the read-out at that concentration, not a potency): 28.4%
For compound 3 the middle estimate is 7.6 percentage points above the measured one, within the range that was stated.
By their numbers in this assay, from the lowest: compound 1; then compound 3; then compound 2.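

In this assay, going by these compounds alone, 3-methylphenyl in place of 4-ethylphenyl on this aromatic carbon gives a number 17.5 percentage points lower from compound 2 to compound 3 (beyond the scatter) and is the first single-place step available, so it is the first direct sign that the group at this position bears on the read-out. Both groups are a six-membered aromatic ring of carbon only, with no hydrogen-bond donors or acceptors and no net charge, so the step lies in the alkyl chain and where it sits on that ring, and this one step cannot separate the two. Nothing on hand bears on why the number falls.

The compounds shown leave open which of those two differences carries the step. They also leave open how a longer chain, an amine or a carboxylic acid on this phenyl ring would read.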